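Hydroxamate series: dropping a fluoro from the sulfonyl aryl

The compounds below may be only part of what the source reports. "The series", "measured", "known", "first", "only" and "open" are said of these compounds alone.

Measured so far:
compound 1, `O=C(NO)c1ccc(N(Cc2ccc(C(F)(F)F)cc2)C(=O)CN(Cc2ccccc2C(F)(F)F)S(=O)(=O)c2ccc(F)cc2)cc1`, 93 nM
compound 2, `CC(C)(C)c1ccc(CN(C(=O)CN(Cc2c(F)c(F)c(F)c(F)c2F)S(=O)(=O)c2ccc(F)cc2)c2ccc(C(=O)NO)cc2)cc1`, 190 nM
compound 3, `CC(C)(C)c1ccc(CN(C(=O)CN(Cc2ccccc2C(F)(F)F)S(=O)(=O)c2ccc(F)cc2F)c2ccc(C(=O)NO)cc2)cc1`, 289 nM

All three share the hydroxamic acid core and were tested in an assay on Sf9 cells for inhibition of protein deacetylase HDAC6 (Homo sapiens), read by mobility shift assay; a lower number here means a stronger inhibitor, a higher number a weaker inhibitor. Compound 3 gives the highest of the three numbers, with 289 nM. Compound 2 stands nearest, at 190 nM, within the scatter, so no order between compounds 2 and 3 can be claimed. Compound 1, at 93 nM, sits beyond the scatter from compound 3, the widest gap in the set; both benzyl groups and the sulfonyl aryl differ between these two, so no single change accounts for it.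

Compound 4, `CC(C)(C)c1ccc(CN(C(=O)CN(Cc2ccccc2C(F)(F)F)S(=O)(=O)c2ccc(F)cc2)c2ccc(C(=O)NO)cc2)cc1`, differs from compound 3 in one place: hydrogen in place of fluoro on an aromatic carbon. Among the measured compounds shown here, no measured pair isolates this change. Compounds 1 and 2 both carry the (4-fluorophenyl)sulfonyl group, but each differs from compound 3 elsewhere as well, so their values cannot be read as this step. The expectation for compound 4 is a small step, if any, not beyond the scatter, leaning slightly toward a lower number: a 1.4-fold lower number from compound 3 to compound 4 (0.14 log units; within the scatter). Compound 4 is therefore estimated at 210 nM, within 90 nM to 480 nM.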

Compound 4, half-maximal inhibitory concentration: 230 nM
The estimate for compound 4 lay 1.1-fold (0.04 log units) below the measured number, and the stated range covers the measured number.
By their numbers in this assay, from the lowest: compound 1; then compounds 2, 4 and 3 (each within the scatter of the next).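

In this assay, the change from 2,4-difluorophenyl to 4-fluorophenyl on the sulfonyl can now be read alone as a 1.3-fold lower number from compound 3 to compound 4 (0.10 log units; within the scatter) and so shows no resolvable effect of the fluoro ortho to a large group. Among the compounds shown here, compound 4 also links the other two compounds by single changes: 2-(trifluoromethyl)phenyl in place of 2,3,4,5,6-pentafluorophenyl gives a 1.2-fold higher number from compound 2 to compound 4 (0.08 log units; within the scatter) and no resolvable effect, while tert-butyl in place of trifluoromethyl gives a 2.5-fold higher number from compound 1 to compound 4 (0.39 log units; beyond the scatter) as the only step here that clears the scatter. No measurement here explains the size of any of these steps.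

On these data alone, whether this aromatic carbon accepts a chloro, a methoxy or an amine remains open. Also open, as far as these compounds go, is whether the tert-butyl step holds with other groups on the sulfonamide nitrogen, since it rests on one pair.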